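A bromophenyl chalcone on the shared triazolopyrimidine core

The source may hold more compounds than are shown below. What is called first, only, known or untested is meant among the compounds shown, and "the series" means these compounds.

Three chalcone analogues built on a shared core have been measured in a functional assay on SW-620 cells (Homo sapiens) for cytotoxicity, read by MTT assay, with stated times of 4 h and 72 h, tested at 2 uM; on this read-out higher numbers stand for weaker inhibition and lower numbers for stronger inhibition. Compound 1 `Cc1cc(Nc2ccc(C(=O)/C=C/c3ccc4ccccc4c3)cc2)n2nc(SCc3cccc4ccccc34)nc2n1` gives 68 nM. Compound 2 `Cc1cc(Nc2ccc(C(=O)/C=C/c3ccc(C(F)(F)F)cc3)cc2)n2nc(SCc3nc4ccccc4[nH]3)nc2n1`, which carries the benzimidazolylmethylthio group, gives 1850 nM. Compound 3 `Cc1cc(Nc2ccc(C(=O)/C=C/c3ccccc3F)cc2)n2nc(SCc3nc4ccccc4[nH]3)nc2n1`, the same scaffold with a 2-fluorophenyl group, gives 250 nM and so stands second highest of the three, above compound 1 and below compound 2 by margins that are beyond the scatter. Within the data shown here, the only single-point step in the set is a 7.4-fold lower number from compound 2 to compound 3 (0.87 log units; beyond the scatter).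

Compound 4 `Cc1cc(Nc2ccc(C(=O)/C=C/c3ccc(Br)cc3)cc2)n2nc(SCc3nc4ccccc4[nH]3)nc2n1` is the next member. Its relation to compound 3 is 4-bromophenyl in place of 2-fluorophenyl on a double-bonded chain carbon bound to a double-bonded chain carbon. The step from compound 2 to compound 3 is the one that bears on it, since it also exchanges the aryl group on the double-bonded chain carbon bound to a double-bonded chain carbon; there the 2-fluorophenyl group gave the lower number. Going the other way, from 2-fluorophenyl to 4-bromophenyl, is therefore expected to move the number back up, though bromine is not trifluoromethyl and the move is expected to be smaller than a 7.4-fold lower number from compound 2 to compound 3 (0.87 log units; beyond the scatter). The expected step is a 2.4-fold higher number from compound 3 to compound 4 (0.38 log units; beyond the scatter). Compound 4 is estimated at 600 nM, within 200 nM to 1800 nM.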

Compound 4, half-maximal inhibitory concentration: 290 nM
Beside the measured number, compound 4's estimate is 2.1-fold (0.32 log units) above it; the range from low to high includes it.
By their numbers in this assay, from the lowest: compound 1; then compounds 3 and 4 (each within the scatter of the next); then compound 2.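

In this assay the exchange of 2-fluorophenyl for 4-bromophenyl on a double-bonded chain carbon bound to a double-bonded chain carbon gives a 1.2-fold higher number from compound 3 to compound 4 (0.06 log units; within the scatter) and so leaves the two aryl groups indistinguishable in this assay, even though they differ in both the halogen and its printed ring number. The second comparison gives a 6.4-fold lower number from compound 2 to compound 4 (0.80 log units; beyond the scatter) for bromo in place of trifluoromethyl on an aromatic carbon, so among these three compounds with the same group on sulfur, compound 2 stands apart from both compound 3 and compound 4, and the earlier step from compound 2 no longer rests on the 2-fluorophenyl group alone. Nothing at hand accounts for the trifluoromethyl compound's separation from the two halogen-bearing aryl analogues.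

The compounds shown leave open whether this level holds for 4-fluorophenyl and 2-bromophenyl, the pair that would separate the halogen from its ring number. They also leave open how a 4-aminophenyl or 4-carboxyphenyl group would read at this place, and compound 1 differs from the others in more than one place, so it settles neither question.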